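The compounds below may be only part of what the source reports. "The series", "measured", "known", "first", "only" and "open" are said of these compounds alone.

Three compounds have so far been measured in an in vitro functional assay on cells (Fibroblast) for agonist activity at Alpha-1D adrenergic receptor (Homo sapiens); a lower number here means that less compound is needed, a higher number that more compound is needed for the effect:

- compound 1 `c1ccc(-c2nc[nH]n2)c(NCC2=NCCN2)c1`: 3.98 nM
- compound 2 `Cn1ncnc1-c1ccccc1NCC1=NCCN1`: 63.1 nM
- compound 3 `CCn1ncnc1-c1ccccc1NCC1=NCCN1`: 126 nM

Compound 3 has the highest number of the three. Its nearest neighbour is compound 2, whose number is lower but within the scatter, so the two cannot be told apart with confidence. Compound 1 stands furthest away, with a number far lower than that of compound 3, a gap well beyond the scatter.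

Compound 4 `CCCn1ncnc1-c1ccccc1NCC1=NCCN1` differs from compound 3 in one place: methyl in place of hydrogen on a saturated chain carbon, two bonds along the chain from an aromatic nitrogen. Within the data shown here, of the two measured steps, only one bears on this change. Going from compound 2 to compound 3 a methyl group was likewise added on that chain, and the result was a 2.0-fold higher number from compound 2 to compound 3 (0.30 log units; within the scatter). The other step, a 16-fold higher number from compound 1 to compound 2 (1.20 log units; beyond the scatter), involved a change to the ring itself and says little about lengthening the chain.

Lengthening the chain once more is therefore expected to give a small step toward a higher number, or none beyond the scatter, estimated as a 1.6-fold higher number from compound 3 to compound 4 (0.20 log units; within the scatter). Compound 4 is expected to give 200 nM, with a range from 80 nM to 500 nM.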

Compound 4, half-maximal effective concentration: 251 nM
Beside the measured number, compound 4's estimate is 1.3-fold (0.10 log units) below it; measured number inside the range.
By their numbers in this assay, from the lowest: compound 1; then compounds 2, 3 and 4 (each within the scatter of the next, the first and the last beyond it).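

In this assay, going from ethyl to propyl gives a 2.0-fold higher number from compound 3 to compound 4 (0.30 log units; within the scatter) and so, like the step from methyl to ethyl, cannot on its own be told apart from the scatter. Taken together, the change from methyl to propyl gives a 4.0-fold higher number from compound 2 to compound 4 (0.60 log units; beyond the scatter) and is the first sign that lengthening this chain has a real, though modest, effect on the number, which neither single addition could show. No measurement at hand explains why the number follows the chain length in this way.

Still open, from the compounds shown here alone, is whether a longer chain such as butyl continues this trend, or whether a chain ending in an amine or a hydroxyl group departs from it. Also open, going by these compounds, is whether any group on this aromatic nitrogen could approach compound 1 at 3.98 nM or would always remain well away from it.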